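A few compounds are considered here, and "the series" means these few. Any claim that something is new, unique, unknown or untested is made for them only; others in the source may bear on it.

Measured compounds:
Compound 1, `CCCNC(=O)N1CCN(c2cc(N)c3cc(OC)c(OC)cc3n2)CC1`: 0.44 nM
Compound 2, `COc1cc2nc(N3CCN(C(=O)c4ccco4)CC3)cc(N)c2cc1OC`: 0.14 nM

In an assay on brain for displacement of a labelled ligand from Adrenergic receptor alpha-1 (Rattus norvegicus) (on this read-out higher numbers stand for weaker inhibition and lower numbers for stronger inhibition), compound 2 gives the lowest of the two numbers shown; its nearest neighbour is compound 1, and the step of a 3.1-fold lower number from compound 1 to compound 2 (0.50 log units; beyond the scatter) lies beyond the scatter, so compound 2 stands as the more strongly inhibiting of the pair.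

Compound 3, `COc1cc2nc(N3CCN(c4nccc(N(C)C)n4)CC3)cc(N)c2cc1OC`, is not yet measured. Relative to compound 2 it carries 4-(dimethylamino)pyrimidin-2-yl in place of (furan-2-yl)carbonyl on an amine nitrogen in a ring. Going by the values given here, the only step measured so far, a 3.1-fold lower number from compound 1 to compound 2 (0.50 log units; beyond the scatter), also alters the group attached to that ring nitrogen, and it shifted this assay only modestly. Among the compounds with values here, no measured step concerns a pyrimidinyl group at this position, so the direction of the change is open. A step of similar modest size, in either direction, is expected for compound 3, roughly a 2.1-fold higher number from compound 2 to compound 3 (0.33 log units; beyond the scatter). Compound 3 is therefore estimated at 0.3 nM, with a range from 0.08 nM to 1.5 nM.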

Compound 3, inhibition constant: 0.46 nM
Estimate against measurement, compound 3: 1.5-fold (0.19 log units) below; measured number inside the range.
By their numbers in this assay, from the lowest: compound 2; then compounds 1 and 3 (each within the scatter of the next).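

In this assay, replacing (furan-2-yl)carbonyl on the ring nitrogen with 4-(dimethylamino)pyrimidin-2-yl settles the direction left open for this change: inhibition is weaker (a 3.3-fold higher number from compound 2 to compound 3 (0.52 log units; beyond the scatter)). Set against propylcarbamoyl, the same group gives no separable difference (a 1.0-fold higher number from compound 1 to compound 3 (0.02 log units; within the scatter)), so compound 1 and compound 3 cannot be told apart. Going by these compounds alone, a carbonyl on the ring nitrogen is therefore not required for a sub-nanomolar reading at this position, although the one compound that stands apart, compound 2, does carry a carbonyl there.

Whether the dimethylamino group contributes remains open, since the plain pyrimidin-2-yl group and a simple acetyl group do not appear among these compounds. Nothing shown here explains the differences between these groups.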